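Working notes: pyridin-2-yl to pyridin-3-yl

The compounds below may be only part of what the source reports. "The series", "measured", "known", "first", "only" and "open" are said of these compounds alone.

Measured in a functional assay on MiaPaCa cells (Homo sapiens) for antiproliferative activity, read by sulforhodamine B assay, with a stated time of 48 h; on this read-out lower numbers stand for stronger inhibition of growth and higher numbers for weaker inhibition of growth:
- compound 1 `O=C1COc2ccccc2N1CCCn1cc(-c2ccccc2)nn1`: 94000 nM
- compound 2 `O=C1COc2ccccc2N1CCCn1cc(-c2ccccn2)nn1`: 5800 nM

Going by the values given here, of the two measured compounds, compound 2 has the lower number, and its only neighbour is compound 1. The next compound to consider is compound 3 `O=C1COc2ccccc2N1CCCn1cc(-c2cccnc2)nn1`. Its difference from compound 2 is pyridin-3-yl in place of pyridin-2-yl on an aromatic carbon. This places pyridin-3-yl in place of pyridin-2-yl on an aromatic carbon of a five-membered aromatic ring with 3 nitrogen.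

Among the compounds with values here, only one measured step bears on this change: a 16-fold lower number from compound 1 to compound 2 (1.21 log units; beyond the scatter). That large step, pyridin-2-yl in place of phenyl, shows that the group on this carbon can shift the number well beyond the scatter. Within the data shown here, no measured compound carries pyridin-3-yl, so the data do not show how much of that step would be kept. A moderate move towards a higher number in this assay is therefore expected, though a result within the scatter of compound 2 remains possible. The estimated change is a 2.8-fold higher number from compound 2 to compound 3 (0.44 log units; beyond the scatter). For compound 3 the expected value is 16000 nM, with an estimated range of 5000 nM to 50000 nM.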

Compound 3, concentration for 50% growth inhibition: 8200 nM
Estimate against measurement, compound 3: 2.0-fold (0.29 log units) above, within the range that was stated.
By their numbers in this assay, from the lowest: compounds 2 and 3 (each within the scatter of the next); then compound 1.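

In this assay, pyridin-3-yl in place of pyridin-2-yl on this aromatic carbon of the five-membered aromatic ring stays within the scatter (a 1.4-fold higher number from compound 2 to compound 3 (0.15 log units; within the scatter)), so the two pyridine isomers cannot be told apart on this read-out. The large step seen earlier is therefore not tied to pyridin-2-yl alone: pyridin-3-yl in place of phenyl also gives a large step (an 11-fold lower number from compound 1 to compound 3 (1.06 log units; beyond the scatter)), alongside the one for pyridin-2-yl (a 16-fold lower number from compound 1 to compound 2 (1.21 log units; beyond the scatter)), and in these three compounds both pyridine isomers stand apart from phenyl. Nothing measured here accounts for either step or for the lack of separation between the two isomers.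

The compounds shown leave open whether pyridin-4-yl on the same carbon would fall with the two pyridine isomers or with phenyl, and whether an amine or a carboxylic acid on the pyridine ring would move the number in this assay at all. They also leave open whether a longer chain linking the core to the five-membered aromatic ring would preserve the gap to phenyl.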